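This account rests on a few compounds, and the source may have more. Where it says the series, first, only, none or still open, it means among the compounds named here.

Measured in an ADME assay on L6 cells (Rattus norvegicus) for cytotoxicity; on this read-out higher numbers stand for weaker inhibition and lower numbers for stronger inhibition:
compound 1 `N=C(N)c1ccc(-c2cc3cc(C(=N)N)ccc3[nH]2)cc1`: 1700 nM
compound 2 `Cc1cc(C(=N)N)ccc1-c1cc2ccc(C(=N)N)cc2[nH]1`: 15700 nM

Of these two, compound 1 stands lowest at 1700 nM, which here means the stronger inhibition, while compound 2 reads 15700 nM, a gap beyond the usual scatter. The next compound, compound 3 `Cc1cc(C(=N)N)ccc1-c1cc2cc(C(=N)N)ccc2[nH]1`, keeps the core of compound 1 and changes it in one place: methyl in place of hydrogen on an aromatic carbon, ortho to a large group and meta to a group of 3 heavy atoms. Going by the values given here, no two measured compounds differ in one place only, so this change has no direct precedent. The expectation rests on compound 2, which also carries a methyl and reads 15700 nM. A moderate rise in this assay is therefore expected, beyond the scatter but uncertain in size, and the estimated step is a 2.9-fold higher number from compound 1 to compound 3 (0.47 log units; beyond the scatter). For compound 3 the expected value is 5000 nM, within an estimated range of 1500 nM to 20000 nM.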

Compound 3, half-maximal inhibitory concentration: 23500 nM
Beside the measured number, compound 3's estimate is 4.7-fold (0.67 log units) below it; measured number outside the range, above it.
By their numbers in this assay, from the lowest: compound 1; then compounds 2 and 3 (each within the scatter of the next).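

In this assay, the methyl in place of hydrogen on an aromatic carbon, ortho to a large group and meta to a group of 3 heavy atoms, gives a 14-fold higher number from compound 1 to compound 3 (1.14 log units; beyond the scatter), a large step toward weaker inhibition. This is the first change in a single place among the compounds shown, and it establishes that one added carbon at this position is enough to move the read-out well beyond the scatter. Nothing available here accounts for the size of this step.

The compounds shown leave open whether an ethyl, a methoxy group or a chlorine on this same carbon would give a step of similar size. They also leave open whether a methyl on another carbon of this ring would do the same.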